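The source may report more compounds than this note shows. Statements on the series, on what has been measured and on what is new or still open speak of the compounds shown alone.

In a functional assay on C6 cells (Rattus norvegicus) for inhibition, read by sulforhodamine B assay, with a stated time of 72 h (on this read-out lower numbers stand for an effect already at smaller amounts and higher numbers for an effect only at larger amounts of compound), compound 1 `O=C(/C=C/c1ccc([N+](=O)[O-])o1)c1ccc(Br)cc1` gives 2700 nM and compound 2 `CC(C)(C)c1ccc(C(=O)/C=C/c2ccc([N+](=O)[O-])o2)cc1` gives 28600 nM, the higher of the two numbers. Compound 3 `CCCCc1ccc(C(=O)/C=C/c2ccc([N+](=O)[O-])o2)cc1` differs from compound 2 in one group: butyl in place of tert-butyl on an aromatic carbon. Going by the values given here, only one measured step bears on this change, and it is large: an 11-fold higher number from compound 1 to compound 2 (1.03 log units; beyond the scatter), with tert-butyl in place of bromo on an aromatic carbon. It shows that this group can move the number, but it does not test butyl, so the expectation is loose. The expected change is a moderate drop, a 3.2-fold lower number from compound 2 to compound 3 (0.50 log units; beyond the scatter), smaller than that step. Compound 3 is estimated at 9000 nM, with an expected range from 2500 nM to 30000 nM.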

Compound 3, half-maximal effective concentration: 1700 nM
Beside the measured number, compound 3's estimate is 5.3-fold (0.72 log units) above it, and the stated range ends above it.
By their numbers in this assay, from the lowest: compounds 3 and 1 (each within the scatter of the next); then compound 2.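

Tert-butyl and butyl hold the same atoms, joined differently, and at this place on the ring that rearrangement alone produces a large shift (a 17-fold lower number from compound 2 to compound 3 (1.23 log units; beyond the scatter)). The high number of compound 2 therefore goes with tert-butyl in particular and not with every carbon group in place of bromo, since butyl in place of bromo leaves the number within the scatter (a 1.6-fold lower number from compound 1 to compound 3 (0.20 log units; within the scatter)). Nothing measured here gives a reason for the gap between these two groups.

Still open, going by these compounds, is whether a longer chain such as hexyl, or a shorter one such as ethyl, would keep the low number of compound 3. An amine or a carboxylic acid at this place is equally untested by these compounds.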